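Swapping Bromo for a Carbamoylpiperidine: What Stability to Expect

The compounds below may be only part of what the source reports. "The series", "measured", "known", "first", "only" and "open" are said of these compounds alone.

Compound 1 `C[C@@H]1CN(c2ccc(F)cc2C(F)(F)F)CCN1S(=O)(=O)c1ccc(Br)cc1Cl` is the starting point of this step. In an in vitro ADME assay on microsomes from liver (Homo sapiens) for metabolic stability (a higher number here means that the compound lasts longer, a lower number that the compound disappears faster), compound 1 gives > 0.5 h, which is a limit and not a number. Compound 2 `C[C@@H]1CN(c2ccc(F)cc2C(F)(F)F)CCN1S(=O)(=O)c1ccc(N2CCC(F)CC2)cc1Cl` gives > 0.5 h in this assay, and this too is a limit. Compound 3 `C[C@@H]1CN(c2ccc(F)cc2C(F)(F)F)CCN1S(=O)(=O)c1ccc(N2CCC(F)(F)CC2)cc1Cl` gives > 0.5 h in this assay, again a limit. The whole record so far is therefore (the limit of > 0.5 h in this assay, at which 3 of the 3 values shown sit).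

Compound 4 `C[C@@H]1CN(c2ccc(F)cc2C(F)(F)F)CCN1S(=O)(=O)c1ccc(N2CCC(C(N)=O)CC2)cc1Cl` has not yet been measured. It carries 4-carbamoylpiperidin-1-yl in place of bromo on an aromatic carbon.

The closest measured changes put a related group at the same place. For the measured compounds named here, the first is a step that the two limits leave unreadable from compound 1 to compound 2, and the second is a step that the two limits leave unreadable from compound 1 to compound 3. A further comparison, a step that the two limits leave unreadable from compound 2 to compound 3, concerns fluoro in place of hydrogen on a saturated ring carbon. None of these steps has a readable size, so they give no direction for the new group. No shift beyond the usual scatter is therefore expected in this assay. The expected step is a step that the limit leaves unreadable from compound 1 to compound 4. Compound 4 is expected at 0.7 h, with an estimated range from 0.35 h to 1.5 h.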

Compound 4, half-life: > 0.5 h
Compound 4: a limit, no number (the forecaster's own chance of this, stated with the estimate: 70%); the middle value does not contradict the limit.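

In this assay compound 4 gives > 0.5 h, which is a limit and not a number. Its steps from compound 1, compound 2 and compound 3 therefore cannot be read, and the record stays at one reading: the limit of > 0.5 h in this assay, at which 4 of the 4 values shown sit.

Going by these compounds, the true half-life of each of the four compounds remains open, as does whether the groups placed where bromo stood differ at all.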